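The source may hold more compounds than are shown below. What is called first, only, known or untested is meant among the compounds shown, and "the series" means these compounds.

Working notes on the series. Two members have been run through an assay on isolated protein for inhibition of aldehyde dehydrogenase 1A1 (Homo sapiens) (on this read-out higher numbers stand for weaker inhibition and lower numbers for stronger inhibition), so far. Compound 1 `CC(Sc1nc2c(cnn2C)c(=O)n1-c1ccccc1)c1ccccn1` gives 242 nM in this assay, and compound 2 `CC(Sc1nc2c(cnn2C)c(=O)n1-c1ccc(CCO)cc1)c1ccccc1` gives 360 nM in this assay. Compound 1 carries the lower of the two readings, but the gap to compound 2 lies within the usual scatter, so the two cannot be separated on these numbers.

Compound 3 `C[C@H](Sc1nc2c(cnn2C)c(=O)n1-c1ccccc1)c1ccccc1` has not yet been measured. It differs from compound 1 in one place: 1-phenylethyl in place of 1-(pyridin-2-yl)ethyl on a sulfur. Among the measured compounds shown here, no measured pair in the set isolates this change, so nothing firm can be drawn from the data about its size; the shift is expected to be small, in the direction of a modestly higher number, if it reaches beyond the scatter at all. Against that background compound 3 is expected to give about 350 nM in this assay, within a range of 150 nM to 800 nM, which corresponds to an expected step of a 1.4-fold higher number from compound 1 to compound 3 (0.16 log units; within the scatter).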

Compound 3, half-maximal inhibitory concentration: 1410 nM
Beside the measured number, compound 3's estimate is 4.0-fold (0.61 log units) below it; measured number outside the range, above it.
By their numbers in this assay, from the lowest: compounds 1 and 2 (each within the scatter of the next); then compound 3.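

Among the compounds shown here, at this place, on a sulfur whose other neighbours are aromatic carbon, the two groups are not interchangeable: in this assay, 1-phenylethyl in place of 1-(pyridin-2-yl)ethyl gives a 5.8-fold higher number from compound 1 to compound 3 (0.77 log units; beyond the scatter), the first step that can be read beyond the scatter. Both groups have the same heavy-atom count and differ by one ring nitrogen, but compound 3 also carries a defined stereocentre, so the step cannot be assigned to the nitrogen alone. Nothing available here accounts for the step.

Still open, on these data alone, is whether the opposite configuration of 1-phenylethyl would read differently, and whether 1-(pyridin-3-yl)ethyl or 1-(pyrimidin-2-yl)ethyl would match 1-(pyridin-2-yl)ethyl. Also open, as far as these compounds go, is whether the same change would give a similar step on the core of compound 2.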